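Shrinking the amide ring: from compound 1 to compound 3

A few compounds are considered here, and "the series" means these few. Any claim that something is new, unique, unknown or untested is made for them only; others in the source may bear on it.

Measured so far:
- compound 1, `N#C[C@@H]1CCCN1C(=O)[C@@H]1C[C@H](C(=O)N2CCCCCCC2)CN1`: 63%
- compound 2, `CCN(C)C(=O)[C@H]1C[C@@H](C(=O)N2CCC[C@H]2C#N)N[C@H]1C`: 92%

Of the compounds shown here, two have been tested in an assay on the whole organism (plasma, strain Sprague-Dawley) for inhibition of Dipeptidyl peptidase 4 (Rattus norvegicus), with a stated time of 6 h, at a dose of 1 mg/kg by the oral route; on this read-out lower numbers stand for less inhibition and higher numbers for more inhibition at the one dose given (going by the name of the read-out). Compound 1 gives 63% in this assay, the lower of the two numbers. Compound 2 differs from compound 1 in several places at once; in this assay compound 2 gives 92%, a gap that lies beyond the usual scatter, and since the two compounds differ in several places nothing beyond that comparison can be read from them.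

Compound 3, `N#C[C@@H]1CCCN1C(=O)[C@@H]1C[C@H](C(=O)N2CCCCCC2)CN1`, has not been measured. It differs from compound 1 in one place only: a group of 7 heavy atoms (6 carbon, 1 nitrogen; one seven-membered non-aromatic ring with 1 hetero atom) in place of a group of 8 heavy atoms (7 carbon, 1 nitrogen; one eight-membered non-aromatic ring with 1 hetero atom), on a carbonyl carbon. Among the measured compounds shown here, no pair of measured compounds differing in just one place is available, so the size of this step has to be estimated rather than read off. For the measured compounds named here, the change is small, and nothing among the measured compounds argues for a large shift in either direction. Compound 3 is therefore expected to land close to compound 1, with a step of a number 5 percentage points higher from compound 1 to compound 3 (within the scatter), which stays within the scatter. The estimate for compound 3 in this assay is 68%, with a range from 45% to 85%.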

Compound 3, a percentage reported as inhibition, in the whole organism at one dose (the size of the read-out at that dose, not a potency): 68%
The estimate for compound 3 equals the measured number at the digits printed, within the range that was stated.
By their numbers in this assay, from the lowest: compounds 1 and 3 (each within the scatter of the next); then compound 2.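

In this assay, putting azepan-1-yl in place of the eight-membered ring on the carbonyl carbon gives a number 5 percentage points higher from compound 1 to compound 3 (within the scatter). This is the first comparison shown in which only this group differs, so it gives a direct reading at this position: here, the seven-membered and eight-membered rings cannot be told apart, and the result is a reading at one dose and one time rather than a measure of potency. No measured information is at hand that would explain this result.

As far as these compounds go, whether the group on this carbonyl carbon can matter more remains open: a piperidine or morpholine ring, or an open-chain amine such as dimethylamine, could stay close to azepan-1-yl or could depart from it. Compound 2 gives 92% in this assay, but it differs from the other two compounds in several places, so that number cannot be assigned to its amide group alone.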